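This account rests on a few compounds, and the source may have more. Where it says the series, first, only, none or still open, it means among the compounds named here.

Measured compounds:
compound 1, `COc1ccc(F)cc1CNCCCNc1ccnc2cc(CCC(C)C)ccc12`, 4200 nM
compound 2, `COc1ccc(F)cc1CNCCCNc1ccnc2cc(Oc3ccc(C(C)(C)C)cc3)ccc12`, 14500 nM
compound 3, `c1ccc(-c2ccc3c(NCCCNCc4ccco4)ccnc3c2)cc1`, 32000 nM

All three were run in a physicochemical assay for solubility, with a stated time of 18 h, at pH 7.4; on this read-out higher numbers stand for higher solubility and lower numbers for lower solubility. Compound 3 stands highest of the three numbers; compound 2 is nearest, and compound 1 furthest, both with steps to compound 3 beyond the scatter. Among the measured compounds shown here, the one measured step within the set, a 3.5-fold higher number from compound 1 to compound 2 (0.54 log units; beyond the scatter), concerns a change on an aromatic carbon and not the place altered in compound 4.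

Compound 4, `COc1ccc(F)cc1CNCCCNc1ccnc2cc(-c3ccccc3)ccc12`, is not yet measured in this assay. It differs from compound 3 by 5-fluoro-2-methoxyphenyl in place of furan-2-yl on a saturated chain carbon bound to an amine nitrogen. For the measured compounds named here, no measured step bears directly on this change. Compounds 1 and 2 both carry the 5-fluoro-2-methoxybenzyl that enters here, and both give lower numbers than compound 3, but they also differ from compound 3 elsewhere, so the comparison is indirect. On that basis a modest downward step is expected, a 2.3-fold lower number from compound 3 to compound 4 (0.36 log units; beyond the scatter), with wide uncertainty. The estimate for compound 4 in this assay is 14000 nM, with a range from 5000 nM to 40000 nM.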

Compound 4, solubility: 32000 nM
Beside the measured number, compound 4's estimate is 2.3-fold (0.36 log units) below it; measured number inside the range.
By their numbers in this assay, from the lowest: compound 1; then compound 2; then compounds 3 and 4 (each within the scatter of the next).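

In this assay, 5-fluoro-2-methoxyphenyl in place of furan-2-yl on a saturated chain carbon bound to an amine nitrogen gives no change at the digits printed from compound 3 to compound 4 (within the scatter), so at this place the swap to the group with more heavy atoms leaves no readable difference. With 5-fluoro-2-methoxybenzyl held constant, the group on the aromatic carbon can now be compared directly: phenyl gives a 2.2-fold higher number from compound 2 to compound 4 (0.34 log units; beyond the scatter) and a 7.6-fold higher number from compound 1 to compound 4 (0.88 log units; beyond the scatter), so the lower numbers of compounds 1 and 2 go with the groups at that carbon, not with the benzyl. Nothing available explains any of these steps.

Going by these compounds, it remains open whether the same swap would also read flat with isopentyl or 4-(tert-butyl)phenoxy on the aromatic carbon. On these data alone, how a basic ring such as pyridin-2-ylmethyl, or a benzyl bearing a carboxylic acid, would read at this place is also open.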